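A few compounds are considered here, and "the series" means these few. Any claim that something is new, unique, unknown or untested is made for them only; others in the source may bear on it.

Within the data shown here, compound 2 `O=C1N(Cc2ccccc2Br)c2cccn2S(=O)(=O)N1Cc1ccccc1` is the only compound with a plain number in an ADME assay on MT4 cells (Homo sapiens) for cytotoxicity, read by MTT assay, with a stated time of 5 days (a lower number here means that less compound is tolerated, a higher number that more compound is tolerated), where compound 2 gives 226000 nM. Compound 1 `C=CCN1C(=O)N(Cc2ccccc2)S(=O)(=O)n2cccc21` reaches only a limit of this assay, > 802000 nM. Compound 3 `N#CCN1C(=O)N(Cc2ccccc2)S(=O)(=O)n2cccc21` differs from compound 2 by cyano in place of 2-bromophenyl on a saturated chain carbon bound to an amide-type nitrogen in a ring. Among the measured compounds shown here, the one measured step that bears on this change, an at least 3.5-fold lower number from compound 1 to compound 2 (0.55 log units; beyond the scatter), ran from vinyl to the 2-bromophenyl group; compound 3 removes that 2-bromophenyl group again in favour of cyano, so a move back toward the limit of > 802000 nM in this assay, at which 1 of the 2 values shown sits, is expected, a 2.7-fold higher number from compound 2 to compound 3 (0.42 log units; beyond the scatter). Compound 3 is therefore estimated at 600000 nM, within a range from 250000 nM to 1500000 nM.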

Compound 3, half-maximal cytotoxic concentration: 180000 nM
For compound 3 the middle estimate is 3.3-fold (0.52 log units) above the measured one; measured number outside the range, below it.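

Here this assay does not separate cyano from 2-bromophenyl on this chain carbon, with a 1.3-fold lower number from compound 2 to compound 3 (0.10 log units; within the scatter). A ring at this place is therefore not required for the gap to vinyl, since cyano, which has no ring, also gives an at least 4.4-fold lower number from compound 1 to compound 3 (0.64 log units; beyond the scatter). For compound 1 the reading is a limit, not a plain number: the limit of > 802000 nM in this assay, at which 1 of the 3 values shown sits.

Going by these compounds, whether vinyl is the exception or compound 2 and compound 3 show the usual level stays open. An amine, a carboxylic acid or a longer chain at this place could help settle that.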